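Swapping a methoxyphenyl for a chlorophenyl on the shared core

A few compounds are considered here, and "the series" means these few. Any claim that something is new, unique, unknown or untested is made for them only; others in the source may bear on it.

Compound 1 `O=C1C=C(Nc2cccc(F)c2)C(=O)c2c1nc1n2[C@H]2OC[C@@H](O)[C@H]2OC1` gives 5500 nM in a functional assay on MCF7 cells (Homo sapiens) for inhibition, read by sulforhodamine B assay; on this read-out higher numbers stand for weaker inhibition and lower numbers for stronger inhibition. Compound 2 `O=C1C=C(Nc2ccc(Br)cc2)C(=O)c2c1nc1n2[C@H]2OC[C@@H](O)[C@H]2OC1` gives 2580 nM. Compound 3 `COc1ccc(NC2=CC(=O)c3nc4n(c3C2=O)[C@H]2OC[C@@H](O)[C@H]2OC4)cc1` gives 5420 nM.

Compound 3 stands second highest of the three numbers, indistinguishable from compound 1 but set apart by a 2.1-fold higher number from compound 2 to compound 3 (0.32 log units; beyond the scatter). Compound 4 `O=C1C=C(Nc2cccc(Cl)c2)C(=O)c2c1nc1n2[C@H]2OC[C@@H](O)[C@H]2OC1` differs from compound 3 by 3-chlorophenyl in place of 4-methoxyphenyl on an amine nitrogen. The step that bears most on this is a 1.0-fold lower number from compound 1 to compound 3 (0.01 log units; within the scatter), where a halogen-bearing phenyl of the same pattern as that entering compound 4 matched the methoxyphenyl; the step of a 2.1-fold higher number from compound 2 to compound 3 (0.32 log units; beyond the scatter) shows a halogen can also lower the number, but at a different position. A step within the scatter, perhaps slightly downward, is therefore expected: a 1.2-fold lower number from compound 3 to compound 4 (0.08 log units; within the scatter). Compound 4 is estimated at 4500 nM, between 2000 nM and 9500 nM.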

Compound 4, half-maximal inhibitory concentration: 4720 nM
For compound 4 the middle estimate is 1.0-fold (0.02 log units) below the measured one; the measured number falls inside the stated range.
By their numbers in this assay, from the lowest: compounds 2, 4, 3 and 1 (each within the scatter of the next, the first and the last beyond it).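

The change from 4-methoxyphenyl to 3-chlorophenyl on this amine nitrogen does not separate the two compounds (a 1.1-fold lower number from compound 3 to compound 4 (0.06 log units; within the scatter)), and neither does chloro in place of fluoro on the aromatic carbon (a 1.2-fold lower number from compound 1 to compound 4 (0.07 log units; within the scatter)). Compound 4 also stays within the scatter of the 4-bromophenyl compound (a 1.8-fold higher number from compound 2 to compound 4 (0.26 log units; within the scatter)), although compound 2 stands beyond the scatter from compound 1 and compound 3. Nothing available explains these results. From the compounds shown here alone, whether an amine or a carboxylic acid on the phenyl ring, or a longer chain in its place, would shift the number remains open.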